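This account rests on a few compounds, and the source may have more. Where it says the series, first, only, none or still open, it means among the compounds named here.

Measured so far:
Compound 1, `COc1ccc(C(=O)/C(=C\c2ccc(O)c([N+](=O)[O-])c2)SCc2ccc(Br)cc2)cc1`, gives 10000 nM in a functional assay on DU-145 cells (Homo sapiens) for inhibition, read by trypan blue exclusion, with a stated time of 96 h; a higher number here means a weaker inhibitor of growth, a lower number a stronger inhibitor of growth.
Compound 2, `O=C(/C(=C\c1c[nH]c2ccccc12)SCc1ccc(F)cc1)c1ccc(Cl)cc1`, gives 1000 nM.
Compound 3, `Cc1ccc(S/C(=C/c2c[nH]c3ccccc23)C(=O)c2ccc(Cl)cc2)cc1`, gives 10000 nM.

Compound 2 stands lowest of the three numbers in this assay, so it is the strongest inhibitor of growth among them. Its nearest neighbour is compound 1, whose number is higher by an amount beyond the scatter, and compound 3 sits the same distance above. Within the data shown here, the only single-point step among the measured compounds is a 10-fold higher number from compound 2 to compound 3 (1.00 log units; beyond the scatter), which concerns the group on the sulfur, not the aryl group on the double bond.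

Compound 4, `CN(C)c1ccc(/C=C(/SCc2ccc(F)cc2)C(=O)c2ccc(Cl)cc2)cc1`, differs from compound 2 in one place: 4-(dimethylamino)phenyl in place of 1H-indol-3-yl on a double-bonded chain carbon bound to a double-bonded chain carbon. Among the measured compounds shown here, no measured step touches this position, so nothing in the data shows how this assay responds to such an exchange; compound 1 carries a different aryl group there, but it also differs from compound 2 elsewhere, so only its own number can be read. With no guide, the step of a 2.5-fold higher number from compound 2 to compound 4 (0.40 log units; beyond the scatter) is expected to be small or modest, most likely toward a higher number. Compound 4 is therefore estimated at 2500 nM, with a range from 500 nM to 10000 nM.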

Compound 4, concentration for 50% growth inhibition: 50000 nM
Compound 4: the middle estimate sits 20-fold (1.30 log units) below what was measured; the whole stated range lies below it.
By their numbers in this assay, from the lowest: compound 2; then compounds 1 and 3 (each within the scatter of the next); then compound 4.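

In this assay, among these compounds, the aryl group on the double-bonded chain carbon clearly matters: replacing 1H-indol-3-yl with 4-(dimethylamino)phenyl gives a 50-fold higher number from compound 2 to compound 4 (1.70 log units; beyond the scatter), the first measured step at this position. The two groups hold the same heavy atoms, so atom count alone does not separate them; what differs is that 1H-indol-3-yl has a five-membered and a six-membered aromatic ring and a hydrogen-bond donor, while 4-(dimethylamino)phenyl has one six-membered aromatic ring and a hydrogen-bond acceptor. Nothing measured here shows which of these differences, if any, accounts for the step.

The compounds shown leave open whether the loss of strength comes from removing 1H-indol-3-yl or from introducing the dimethylamino group, a question that a plain phenyl or a 1-methyl-1H-indol-3-yl group at this position could help to separate. On these data alone, it also remains open whether this exchange would have a similar effect with a group other than 4-fluorobenzyl on the sulfur, such as the 4-methylphenyl of compound 3.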